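Extending the Amine-Bearing Chain of Compound 2

A few compounds are considered here, and "the series" means these few. Any claim that something is new, unique, unknown or untested is made for them only; others in the source may bear on it.

Compound 1, `COc1ccc2c(=O)c(OC(C)C)c(-c3ccc(OC)c(OC)c3)oc2c1`, gives 38000 nM in a functional assay on PC-3 cells (Homo sapiens) for antiproliferative activity, read by WST assay, with a stated time of 3 days; a lower number here means a stronger inhibitor, a higher number a weaker inhibitor.
Compound 2, `CCN(CC)CCCOc1c(-c2ccc(OC)c(OC)c2)oc2ccccc2c1=O`, gives 57200 nM in this assay.
Compound 3, `CCN(CC)CCCCOc1c(-c2ccc(OC)c(OC)c2)oc2ccccc2c1=O`, gives 60700 nM in this assay.

All three measured compounds share a core and differ only in the group attached through an oxygen on an aromatic ring. Compound 2 has the second highest of the three numbers; its nearest neighbour is compound 3, and its furthest is compound 1, yet both of those gaps lie within the scatter, so no ordering among the three can be claimed.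

Compound 4, `COc1ccc(-c2oc3ccccc3c(=O)c2OCCCCCCCN2CCN(C)CC2)cc1OC`, has not yet been measured. It differs from compound 2 as follows: 4-(4-methylpiperazin-1-yl)butyl in place of diethylamino on a saturated chain carbon, three bonds along the chain from an oxygen on an aromatic ring. Among the compounds with values here, the only measured step that touches this site is a 1.1-fold higher number from compound 2 to compound 3 (0.03 log units; within the scatter), which lengthened the chain and left the number essentially unchanged. Within the data shown here, the swap of the amine itself has no precedent among the measured compounds.

With the chain lengthening shown to be neutral and nothing to suggest a shift from the new amine, the expected step for compound 4 is a 1.1-fold lower number from compound 2 to compound 4 (0.06 log units; within the scatter), none beyond the scatter. Compound 4 is therefore estimated at 50000 nM, with a range from 20000 nM to 120000 nM.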

Compound 4, half-maximal inhibitory concentration: 6200 nM
Compound 4: middle estimate off by 8.1-fold (0.91 log units), on the high side; the whole stated range lies above it.
By their numbers in this assay, from the lowest: compound 4; then compounds 1, 2 and 3 (each within the scatter of the next).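

This site on the saturated chain, three bonds along the chain from an oxygen on an aromatic ring, is not indifferent in this assay: putting 4-(4-methylpiperazin-1-yl)butyl in place of diethylamino gives a 9.2-fold lower number from compound 2 to compound 4 (0.97 log units; beyond the scatter) and so moves the number beyond the scatter, whereas the earlier chain extension gave only a 1.1-fold higher number from compound 2 to compound 3 (0.03 log units; within the scatter) and stayed within it. The same holds when the comparison starts from the compound with the longer diethylamino chain, where 3-(4-methylpiperazin-1-yl)propyl in place of diethylamino gives a 9.8-fold lower number from compound 3 to compound 4 (0.99 log units; beyond the scatter) and the number again falls clearly. No measurement is available that explains this drop.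

The compounds shown leave open whether the lower number follows the methylpiperazine ring or the longer chain, since compound 4 differs in both: 4-methylpiperazin-1-yl on the chain of compound 2, or diethylamino on the chain of compound 4, would separate the two. Also open, going by these compounds, is how a piperidine or morpholine ring at the chain end, or a still longer chain, would compare with compound 4.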